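A few compounds are considered here, and "the series" means these few. Any claim that something is new, unique, unknown or untested is made for them only; others in the source may bear on it.

Three compounds share one core and differ only in the group attached through a saturated chain carbon bound to an oxygen on an aromatic ring. In a functional assay on HepG2 cells (Homo sapiens) for antiproliferative activity, read by MTT assay, with a stated time of 24 h (on this read-out higher numbers stand for weaker inhibition and lower numbers for stronger inhibition), compound 1 `COc1cc(OC)c(-c2coc3cc(OCc4ccccc4)ccc3c2=O)cc1OC` gives 1320 nM, compound 2 `COc1cc(OC)c(-c2coc3cc(OCc4ccccc4C)ccc3c2=O)cc1OC` gives 1860 nM, and compound 3 `COc1cc(OC)c(-c2coc3cc(OCc4cccc(F)c4)ccc3c2=O)cc1OC` gives 1230 nM. Compound 2 carries the highest number of the three, yet both a 1.4-fold higher number from compound 1 to compound 2 (0.15 log units; within the scatter) and a 1.5-fold lower number from compound 2 to compound 3 (0.18 log units; within the scatter) stay within the scatter, so no order can be read from them. Compound 4 `COc1cc(OC)c(-c2coc3cc(OCc4cccc(Br)c4)ccc3c2=O)cc1OC` is not yet measured; it differs from compound 2 by 3-bromophenyl in place of 2-methylphenyl on a saturated chain carbon bound to an oxygen on an aromatic ring. Among the compounds with values here, the nearest precedent is a 1.5-fold lower number from compound 2 to compound 3 (0.18 log units; within the scatter), and a 1.1-fold lower number from compound 1 to compound 3 (0.03 log units; within the scatter) also shows no real movement, so for compound 4 only a 1.4-fold lower number from compound 2 to compound 4 (0.16 log units; within the scatter) is expected, within the scatter. Compound 4 is therefore estimated at 1300 nM, between 650 nM and 2600 nM.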

Compound 4, half-maximal inhibitory concentration: 870 nM
For compound 4 the middle estimate is 1.5-fold (0.17 log units) above the measured one, within the range that was stated.
By their numbers in this assay, from the lowest: compounds 4, 3, 1 and 2 (each within the scatter of the next, the first and the last beyond it).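

In this assay, within the data shown here, the change from 2-methylphenyl to 3-bromophenyl gives the first step at this position beyond the scatter, a 2.1-fold lower number from compound 2 to compound 4 (0.33 log units; beyond the scatter), though a modest one. Bromo cannot be told apart from fluoro (a 1.4-fold lower number from compound 3 to compound 4 (0.15 log units; within the scatter)) or from hydrogen (a 1.5-fold lower number from compound 1 to compound 4 (0.18 log units; within the scatter)), so the only real gap lies between compound 2 and compound 4. Nothing available explains that gap.

Compound 2 and compound 4 differ in both the group and its printed ring number, so a 2-bromophenyl or 3-methylphenyl group would be needed to separate these. As far as these compounds go, an amine or a carboxylic acid on that ring, or a longer chain, remains open.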